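Methoxylation of a phenolic chalcone and its effect on RAW264.7 viability

The source may hold more compounds than are shown below. What is called first, only, known or untested is meant among the compounds shown, and "the series" means these compounds.

Measured compounds:
compound 1, `COc1cc(/C=C/C(=O)c2cccc(O)c2)ccc1O`, 96.9%
compound 2, `COc1ccc(CCC(=O)c2ccc(OC)c(OC)c2)cc1O`, 95.6%
compound 3, `COc1ccc(/C=C/C(=O)c2cccc(O)c2)c(OC)c1`, 97.7%

In an ADME assay on RAW264.7 cells (Mus musculus) for cytotoxicity, read by MTT assay, with a stated time of 24 h, tested at 1.25 ug/mL (on this read-out higher numbers stand for a weaker effect at the one concentration tested and lower numbers for a stronger effect), compound 1 gives 96.9%. The three numbers lie within the usual scatter of one another; the number of compound 1 sits between those of compound 3, which gives 97.7%, and compound 2, which gives 95.6%, and neither gap is more than the scatter of repeated measurements. None of the three compounds can therefore be called weaker or stronger than another on this read-out.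

Compound 4, `COc1ccc(/C=C/C(=O)c2cccc(O)c2)cc1OC`, has not yet been measured. It differs from compound 1 in one place: methyl in place of hydrogen on an oxygen on an aromatic ring. Within the data shown here, no measured pair in this set differs in one place, so there is no step of known size to lean on. Since compound 1 gives 96.9% and the other two compounds stay close to it, the step from compound 1 to compound 4 in this assay is expected to be none beyond the scatter, as a number 0.1 percentage points higher from compound 1 to compound 4 (within the scatter). Compound 4 is estimated at 97%, with a range from 90% to 100%.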

Compound 4, a percentage reported as activity, at one concentration (the size of the read-out at that concentration, not a potency): 101%
Beside the measured number, compound 4's estimate is 4 percentage points below it; the measured number lies above the stated range.
By their numbers in this assay, from the lowest: compounds 2, 1, 3 and 4 (each within the scatter of the next).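

In this assay, the change from hydroxy to methoxy on this aromatic ring comes to a number 4.1 percentage points higher from compound 1 to compound 4 (within the scatter). Among these compounds, the earlier compounds included no pair differing in one place, so this is the first direct reading of the change: with methyl in place of hydrogen on this oxygen, the read-out stays within the scatter at the one concentration tested. Nothing available explains this result.

The compounds shown leave open whether a longer chain on this oxygen, or an amine in place of the methoxy group, would also stay within the scatter. They also leave open whether the same change would remain within the scatter at concentrations higher than the one tested.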